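The compounds below may be only part of what the source reports. "The series", "measured", "known", "first", "only" and "open" are said of these compounds alone.

Measured so far in an in vitro ADME assay on microsomes from liver (Homo sapiens) for metabolic stability, tested at 0.2 uM; on this read-out higher numbers stand for fast clearance and lower numbers for slow clearance:
- compound 1 `Cc1ccc2[nH]c(COc3cccc(OCC4CCOCC4)c3)c(C)c(=O)c2c1`: "not determined" (no result reported)
- compound 2 `Cc1c(COc2cc(OCC3CCOCC3)ccn2)[nH]c2ccccc2c1=O`: 113 mL/min/kg

Compound 1 is the starting point of this step, but it has no number to start from. For compound 1 the record reads "not determined" (no result reported), so its place in the series cannot be stated. The only clearance figure available is that of compound 2, at 113 mL/min/kg.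

Still to be measured is compound 3 `Cc1c(COc2cccc(OCC3CCOCC3)c2)[nH]c2ccc(-c3cccnc3)cc2c1=O`. The structural change is pyridin-3-yl in place of methyl on an aromatic carbon, in a six-membered aromatic ring of carbon only that is part of a fused system of two rings.

Among the measured compounds shown here, no measured step shows what such a replacement does, and the missing number for compound 1 leaves no baseline. The working expectation in this assay is therefore no step beyond the scatter, in either direction, with the value of compound 2 at 113 mL/min/kg as the sole reference. This is a weak basis, and the range is kept wide to reflect it. For compound 3 the estimated clearance is 95 mL/min/kg, with an expected range of 40 mL/min/kg to 190 mL/min/kg.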

Compound 3, clearance: 756 mL/min/kg
The estimate for compound 3 lay 8.0-fold (0.90 log units) below the measured number, and the stated range ends below it.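

Among the compounds shown here, with compound 1 at "not determined" (no result reported) and compound 3 at 756 mL/min/kg in this assay no step between the two can be read. The compounds shown leave open what pyridin-3-yl in place of methyl does to clearance on the shared core. No available data bear on the cause of this result.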